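The compounds below may be only part of what the source reports. "The series", "measured", "known", "first", "only" and "open" are said of these compounds alone.

Measured so far in an ADME assay on Vero cells (Chlorocebus sabaeus) for cytotoxicity, with a stated time of 7 days; on this read-out higher numbers stand for lower toxicity in this test and lower numbers for higher toxicity in this test:
- compound 1 `COc1ccc2[nH]c(C(=O)N3CC(=O)N(Cc4ccccc4)[C@@H](COc4ccccc4)C3)cc2c1`: > 10000 nM, a limit of the assay rather than a number
- compound 2 `COc1ccc2[nH]c(C(=O)N3CC(=O)N(Cc4cccc(OC(F)F)c4)[C@@H](CN4CC5CCC4C5)C3)cc2c1`: 26900 nM

Compound 1 stands at the limit of this assay; the read given for it is a limit and not a number, and the limit of > 10000 nM in this assay, at which 1 of the 2 values shown sits, is where one of the two values sits. Within the data shown here, compound 2 is the only member with a numeric read, and that read places it well out toward the low-toxicity end of the scale. Among the measured compounds shown here, both values together say only that neither compound shows marked cytotoxicity on these cells over the stated time. For the measured compounds named here, no step between the two is given, as they differ in more than one place.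

Compound 3 `COc1ccc2[nH]c(C(=O)N3CC(=O)N(Cc4ccccc4)[C@@H](CN4CC5CC5C4)C3)cc2c1` is not yet measured. Set against compound 1, the change is a group of 6 heavy atoms (5 carbon, 1 nitrogen; one three-membered non-aromatic ring of carbon only, one five-membered non-aromatic ring with 1 hetero atom) in place of a group of 7 heavy atoms (6 carbon, 1 oxygen; one six-membered aromatic ring of carbon only), on a saturated chain carbon bound to a saturated ring carbon.

The expected step that the limit leaves unreadable from compound 1 to compound 3 is one of no change beyond the usual scatter, since the numeric read of compound 2, which carries a related saturated bicyclic amine on the same chain, is 26900 nM and sits in the low-toxicity region of the scale. The read of compound 1 is a limit of the assay lying in that same region. Compound 3 is accordingly estimated at 20000 nM, with a range from 8000 nM to 50000 nM, and a real chance that this assay again reports only a limit.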

Compound 3, half-maximal cytotoxic concentration: 13800 nM
Estimate against measurement, compound 3: 1.4-fold (0.16 log units) above, and the stated range covers the measured number.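

No new step can be read: in this assay the read of compound 1 is a limit and not a number, so its difference from compound 3 stays unreadable: the limit of > 10000 nM in this assay, at which 1 of the 3 values shown sits.

The compounds shown leave open whether replacing the phenoxy group on the saturated chain carbon changes the read-out at all, and by how much.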